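Swapping methoxy for chloro on the pendant aryl ring

A few compounds are considered here, and "the series" means these few. Any claim that something is new, unique, unknown or untested is made for them only; others in the source may bear on it.

Compound 1 `CC(c1ccc(-c2ccccc2)c(F)c1)c1nnc2n1N=C(c1ccc(Cl)cc1Cl)CS2` and compound 2 `COc1ccc(C2=Nn3c(nnc3C(C)c3ccc(-c4ccccc4)c(F)c3)SC2)cc1` share one core and differ only in the aryl group attached to the carbon that carries a double bond to nitrogen. In a functional assay on Huh-7 cells (Homo sapiens) for inhibition, read by sulforhodamine B assay, with a stated time of 72 h (on this read-out lower numbers stand for stronger inhibition and higher numbers for weaker inhibition), compound 1 gives 3700 nM, and compound 2 gives 4300 nM. The step of a 1.2-fold higher number from compound 1 to compound 2 (0.07 log units; within the scatter) shows that exchanging 2,4-dichlorophenyl for 4-methoxyphenyl left the read-out essentially unchanged. Among the two numbers so far, compound 2 carries the higher one, yet its nearest neighbour, compound 1, sits within the scatter of it, so no order between them can be claimed.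

Compound 3 `CC(c1ccc(-c2ccccc2)c(F)c1)c1nnc2n1N=C(c1ccc(Cl)cc1)CS2` is the next member of the series and has not yet been tested. It differs from compound 2 by chloro in place of methoxy on an aromatic carbon, which amounts to 4-methoxyphenyl becoming 4-chlorophenyl. For the measured compounds named here, the only step that bears on this position is a 1.2-fold higher number from compound 1 to compound 2 (0.07 log units; within the scatter), a change that stayed within the scatter. Compound 3 is therefore expected to lie close to compound 2, with a step of about a 1.1-fold lower number from compound 2 to compound 3 (0.03 log units; within the scatter) in this assay. The estimate for compound 3 is 4000 nM, within a range from 2000 nM to 8000 nM.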

Compound 3, half-maximal inhibitory concentration: 3900 nM
The estimate for compound 3 lay 1.0-fold (0.01 log units) above the measured number; measured number inside the range.
By their numbers in this assay, from the lowest: compounds 1, 3 and 2 (each within the scatter of the next).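

In this assay, the step of a 1.1-fold lower number from compound 2 to compound 3 (0.04 log units; within the scatter) isolates a single exchange, chloro in place of methoxy on an aromatic carbon para to a large group, and the two numbers cannot be told apart. The earlier comparison of compound 1 and compound 2 could not show this, since 2,4-dichlorophenyl and 4-methoxyphenyl differ in more than one place on the ring. The step of a 1.1-fold higher number from compound 1 to compound 3 (0.02 log units; within the scatter) adds a separate reading for hydrogen in place of chloro, which also stays within the scatter, so 2,4-dichlorophenyl, 4-chlorophenyl and 4-methoxyphenyl are indistinguishable on this read-out, and nothing in hand accounts for that similarity.

The compounds shown leave open whether any group at this ring position would separate itself from these three, for instance an amine, a carboxylic acid or a longer alkoxy chain in place of the chloro of compound 3. They also leave open whether the same flat reading would hold if the 4-chlorophenyl ring itself gave way to a pyridine or a saturated ring such as cyclohexyl.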